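A few compounds are considered here, and "the series" means these few. Any claim that something is new, unique, unknown or untested is made for them only; others in the source may bear on it.

Measured so far, in an assay on isolated protein for displacement of a labelled ligand from metabotropic glutamate receptor 5 (Homo sapiens), with a stated time of 60 min, tested at 1 uM; on this read-out higher numbers stand for more inhibition at the one concentration tested (going by the name of the read-out) and lower numbers for less inhibition:
compound 1 `CC1CCN(c2c(S(=O)(=O)c3ccc(Cl)c(Cl)c3)cnc3ccc(Cl)cc23)CC1` gives 86%
compound 2 `COc1ccc(S(=O)(=O)c2cnc3ccc(F)cc3c2N2CCC(C)CC2)cc1` gives 85%

Of the two numbers, compound 2 stands lowest, with compound 1 one point higher; this lies within the scatter, so the two are not told apart. Going by the values given here, compound 1 and compound 2 differ in more than one place, and no single step between them has been worked out.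

Compound 3 `CC1CCN(c2c(S(=O)(=O)c3ccc(Cl)c(Cl)c3)cnc3ccc(F)cc23)CC1` is not yet measured. It differs from compound 2 in one place: 3,4-dichlorophenyl in place of 4-methoxyphenyl on a sulfonyl sulfur. Among the compounds with values here, no step between measured compounds is available for this change. Since compound 1 already carries 3,4-dichlorophenyl on a sulfonyl sulfur and gives 86% in this assay, no movement beyond the scatter in either direction is expected. Compound 3 is therefore expected to give 85% in this assay, with a range of 72% to 95%, which means an expected step of no change at the digits printed from compound 2 to compound 3 (within the scatter).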

Compound 3, a percentage reported as inhibition, at one concentration (the size of the read-out at that concentration, not a potency): 91%
Estimate against measurement, compound 3: 6 percentage points below, and the stated range covers the measured number.
By their numbers in this assay, from the lowest: compounds 2, 1 and 3 (each within the scatter of the next).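

In this assay, the change to 3,4-dichlorophenyl in place of 4-methoxyphenyl on a sulfonyl sulfur gives a number 6 percentage points higher from compound 2 to compound 3 (within the scatter), and fluoro in place of chloro on an aromatic carbon gives a number 5 percentage points higher from compound 1 to compound 3 (within the scatter). Neither change can be told from the scatter, so these two groups on the sulfonyl sulfur are not separated in this series, and neither are fluoro and chloro at that aromatic carbon. Nothing measured here bears on these steps.

A read-out at one concentration leaves open whether compound 1, compound 2 and compound 3 would show a stronger or weaker effect at other concentrations. Going by these compounds, it is also open whether a carboxylic acid or an amine in place of the aryl group on the sulfonyl sulfur would move the number beyond the scatter.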